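The source may report more compounds than this note shows. Statements on the series, on what has been measured and on what is new or still open speak of the compounds shown alone.

Measured in a toxicity assay on HT-29 cells (Homo sapiens) for cytotoxicity; a lower number here means that less compound is tolerated, a higher number that more compound is tolerated:
Compound 1 `CN1C(=S)[C@@H](NC(=O)c2n[nH]c(Cc3ccccc3)n2)COc2ccccc21`: > 50000 nM, a limit
Compound 2 `CCCCCn1nc(C(=O)N[C@H]2COc3ccccc3N(C)C2=S)nc1Cc1ccccc1`: > 100000 nM, a limit
Compound 3 `CC(C)CCn1nc(C(=O)N[C@H]2COc3ccccc3N(C)C2=S)nc1Cc1ccccc1`: > 100000 nM, a limit

Among the measured compounds shown here, no compound has yet given a number. Compound 3 is known only through its limit of > 100000 nM. Compound 4 `CN1C(=S)[C@@H](NC(=O)c2nc(Cc3ccccc3)n(CCCCCC#N)n2)COc2ccccc21` differs from compound 3 as follows: 3-cyanopropyl in place of isopropyl on a saturated chain carbon, two bonds along the chain from an aromatic nitrogen. That is 3-cyanopropyl in place of isopropyl on a saturated chain carbon, two bonds along the chain from an aromatic nitrogen.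

For the measured compounds named here, two measured steps bear on this change: a step that the two limits leave unreadable from compound 2 to compound 3, at the same place, and a step that the two limits leave unreadable from compound 1 to compound 3. Neither offers a size to carry over. The expected step is a number no higher from compound 3 to compound 4 (the limit leaves the size open), with no change beyond the scatter foreseen in this assay in either direction. For compound 4 the estimate is 100000 nM, with an expected range from 40000 nM to 200000 nM.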

Compound 4, half-maximal cytotoxic concentration: > 100000 nM
Compound 4: a limit, no number; the forecaster's own chance of this, stated with the estimate: 80%; the middle value sits exactly at the limit.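

Compound 4 gives > 100000 nM as a limit, so no new step can be read from compound 1, compound 2 or compound 3 to it. The compounds shown leave open whether the chain on the aromatic nitrogen changes the half-maximal cytotoxic concentration at all.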